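A few compounds are considered here, and "the series" means these few. Any claim that something is new, unique, unknown or untested is made for them only; others in the source may bear on it.

Measured in a functional assay on MCF7 cells (Homo sapiens) for cytotoxicity, read by sulforhodamine B assay, with a stated time of 48 h; on this read-out higher numbers stand for weaker inhibition of growth and lower numbers for stronger inhibition of growth:
compound 1, `COc1cc(/C(Cl)=C/C=C(\C#N)C(=O)c2c[nH]c3ccc(Br)cc23)cc(OC)c1OC`: 96500 nM
compound 2, `N#C/C(=C\C=C(/Cl)c1ccc(Br)cc1)C(=O)c1c[nH]c2ccccc12`: 81500 nM
compound 3, `COc1ccc(/C(Cl)=C/C=C(\C#N)C(=O)c2c[nH]c3ccccc23)cc1`: > 100000 nM, a limit of the assay and not a number

Compound 4, `COc1ccc2[nH]cc(C(=O)/C(C#N)=C/C=C(\Cl)c3cc(OC)c(OC)c(OC)c3)c2c1`, has not yet been measured in this assay. Compound 1 and compound 2 are built on different cores, but the difference between the two cores is not broken down here; their values in this assay lie within the usual scatter of each other. Compound 3 carries the change of interest: methoxy in place of bromo on an aromatic carbon. That step gave an at least 1.2-fold higher number from compound 2 to compound 3 (0.08 log units; that floor lies within the scatter), and since compound 3 sits at the limit of > 100000 nM in this assay, at which 1 of the 3 values shown sits, the full size of the step is not known. Compound 4 carries the same kind of change relative to compound 1: methoxy in place of bromo on an aromatic carbon. The surroundings differ, though: in compound 3 the change sits on a six-membered aromatic ring of carbon only, para to a large group, whereas in compound 4 it sits on a ring that is part of a fused or bridged system of two rings, meta to a fused ring and para to a fused ring. Because compound 1 already gives 96500 nM and because the earlier step gave an at least 1.2-fold higher number from compound 2 to compound 3 (0.08 log units; that floor lies within the scatter), compound 4 is expected to shift by a 1.2-fold higher number from compound 1 to compound 4 (0.08 log units; within the scatter). The estimate for compound 4 is therefore 115000 nM, expected to fall between 60000 nM and 250000 nM, with a fair chance that only a limit is reported.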

Compound 4, concentration for total growth inhibition: > 100000 nM
Compound 4: a limit, no number (the forecaster's own chance of this, stated with the estimate: 60%); the middle value is on the limit's open side.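

In this assay compound 4 gives > 100000 nM, a limit of the assay and not a number, so the swap of bromo for methoxy on the fused system of two rings can be read only as a floor, the smallest size the step could have: an at least 1.0-fold higher number from compound 1 to compound 4 (0.01 log units; that floor lies within the scatter). Set side by side, the two steps show that neither methoxy compound gives stronger inhibition of growth than its bromo partner, but they do not show that the change has the same effect on both cores: the same change on two cores in this assay, an at least 1.2-fold higher number (0.08 log units; that floor lies within the scatter) from compound 2 to compound 3 and an at least 1.0-fold higher number (0.01 log units; that floor lies within the scatter) from compound 1 to compound 4; the limit leaves it open whether they differ. Going by these compounds, the true size of each step stays unknown, because both methoxy compounds end at the same limit: the limit of > 100000 nM in this assay, at which 2 of the 4 values shown sit.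

The compounds shown leave open whether another group on the same aromatic carbon, such as an amine or a carboxylic acid, would give a real number clearly apart from those of compound 1 and compound 2. They also leave open what the core itself contributes, as no step shown here isolates that difference.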